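The source may hold more compounds than are shown below. What is called first, only, known or untested is meant among the compounds shown, and "the series" means these compounds.

Values in a functional assay on HCT-116 cells (Homo sapiens) for antiproliferative activity, read by MTT assay, with a stated time of 24 h; on this read-out lower numbers stand for stronger inhibition and higher numbers for weaker inhibition:
Compound 1 `COc1ccc(/C=C/C(=O)c2ccc(OC)c3c2OC(C)(C)C=C3)cn1`: > 10000 nM (a limit)
Compound 2 `COc1ccc(C(=O)/C=C/c2ccsc2)c2c1C=CC(C)(C)O2`: > 10000 nM (a limit)
Compound 3 `COc1ccc(C(=O)/C=C/c2ccccn2)c2c1C=CC(C)(C)O2`: 6630 nM

Among the compounds with values here, compound 3 gives the only true number in this set, 6630 nM. The other two results are the limit of > 10000 nM in this assay, at which 2 of the 3 values shown sit.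

The next compound is compound 4 `COc1ccc(C(=O)/C=C/c2ccc(Cl)c(Cl)c2)c2c1C=CC(C)(C)O2`. Its change from the previous compound is 3,4-dichlorophenyl in place of pyridin-2-yl on a double-bonded chain carbon bound to a double-bonded chain carbon, so 3,4-dichlorophenyl stands in place of pyridin-2-yl on a double-bonded chain carbon bound to a double-bonded chain carbon.

Two measured changes at this same place bear on it: an at least 1.5-fold lower number from compound 1 to compound 3 (0.17 log units; that floor lies within the scatter) and an at least 1.5-fold lower number from compound 2 to compound 3 (0.17 log units; that floor lies within the scatter). Both floors lie within the scatter. The third change, a step that the two limits leave unreadable from compound 1 to compound 2, cannot be sized. None of the three involves 3,4-dichlorophenyl, so they suggest no direction, and no shift beyond the scatter is expected.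

The expected change is a 1.1-fold lower number from compound 3 to compound 4 (0.04 log units; within the scatter). Compound 4 is estimated at 6000 nM, with an expected range of 2000 nM to 12000 nM.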

Compound 4, half-maximal inhibitory concentration: 9440 nM
For compound 4 the middle estimate is 1.6-fold (0.20 log units) below the measured one, and the stated range covers the measured number.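

In this assay, within the data shown here, the step of a 1.4-fold higher number from compound 3 to compound 4 (0.15 log units; within the scatter) gives the first comparison at this place between two true numbers rather than limits. At this place, on a double-bonded chain carbon bound to a double-bonded chain carbon, 3,4-dichlorophenyl, a ring of carbon only with 0 hydrogen-bond acceptors, stands in for pyridin-2-yl, a ring with 1 hetero atom and 1 hydrogen-bond acceptor, with no shift beyond the scatter. Two further steps, an at least 1.0-fold lower number from compound 2 to compound 4 (0.02 log units; that floor lies within the scatter) and an at least 1.0-fold lower number from compound 1 to compound 4 (0.02 log units; that floor lies within the scatter), give only floors within the scatter, because their starting values are limits: the limit of > 10000 nM in this assay, at which 2 of the 4 values shown sit.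

The compounds shown leave open whether any group at this place can move the number beyond the scatter. An amine or a carboxylic acid on the ring at this place would be one test of that.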